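The source may report more compounds than this note shows. Statements on the series, on what has been measured and on what is new or still open speak of the compounds shown alone.

Compound 2 `Cc1cccc(-c2nc3c(NC4CCCC4)ncnc3n2C)c1` is the reference point. For the measured compounds named here, in an assay on CHO cells for displacement of a labelled ligand from adenosine receptor A1 (Homo sapiens), read by scintillation counting, with a stated time of 3 h (a higher number here means a weaker inhibitor, a lower number a stronger inhibitor), compound 2 gives 6.2 nM, the lowest of the two numbers measured so far. Going by the values given here, the only comparator is compound 1 `Cn1c(-c2ccccc2Cl)nc2c(NC3CCCC3)ncnc21`, which in this assay gives 37 nM; the step of a 6.0-fold lower number from compound 1 to compound 2 (0.78 log units; beyond the scatter) exchanges the whole aryl group and is the single measured step in the set. Compound 3 `Cn1c(-c2ccccc2)nc2c(NC3CCCC3)ncnc21` differs from compound 2 by hydrogen in place of methyl on an aromatic carbon, that is, the 3-methylphenyl becomes phenyl. Among the compounds with values here, no measured step bears directly on removing this methyl: the step from compound 1 to compound 2 changes both the substituent and its place on the ring, so it gives only a loose sense of scale, showing that changes on this aryl group can move the number modestly. A small loss, perhaps inside the scatter, is therefore expected for compound 3 in this assay, a step of a 1.9-fold higher number from compound 2 to compound 3 (0.29 log units; within the scatter). The estimate for compound 3 is 12 nM, with a range of 5 nM to 30 nM.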

Compound 3, inhibition constant: 2.8 nM
The estimate for compound 3 lay 4.3-fold (0.63 log units) above the measured number, outside the stated range (below it).
By their numbers in this assay, from the lowest: compound 3; then compound 2; then compound 1.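

In this assay, for the compounds shown here, compound 3 gives the first direct reading of the methyl on the aryl group: a 2.2-fold lower number from compound 2 to compound 3 (0.35 log units; beyond the scatter), so hydrogen is favoured over methyl here, and this small removal moves the number beyond the scatter. The bare phenyl also sets a common baseline for the earlier aryl change, with a 13-fold lower number from compound 1 to compound 3 (1.12 log units; beyond the scatter), so among these three compounds both substituted rings give higher numbers than the unsubstituted one, and the chloro removal is the larger step. Nothing available explains either step.

From the compounds shown here alone, it remains open whether any group at the methyl's place can improve on hydrogen, for example a hydroxyl, an amine or a carboxylic acid. The compounds shown also leave open whether a chloro at that same place would behave like the methyl, or like the chloro of the 2-chlorophenyl.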